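From a 4-bromophenyl to a 3-methoxyphenyl amide

The source may report more compounds than this note shows. Statements on the series, on what has been measured and on what is new or still open speak of the compounds shown alone.

Compound 1 `CN(C)C(=O)c1cc2cnc(Nc3ccc(NC(=O)C4(C(=O)Nc5cccc(F)c5)CC4)cc3)nc2n1C1CCCC1` gives -0.4%
Compound 2 `CN(C)C(=O)c1cc2cnc(Nc3ccc(NC(=O)C4(C(=O)Nc5cccc(Cl)c5)CC4)cc3)nc2n1C1CCCC1` gives 92.6%
Compound 3 `CN(C)C(=O)c1cc2cnc(Nc3ccc(NC(=O)C4(C(=O)Nc5ccc(Br)cc5)CC4)cc3)nc2n1C1CCCC1` gives 94.3%

In a functional assay on T47D cells (Homo sapiens) for inhibition, read by CCK-8 assay, with a stated time of 72 h, tested at 10 uM (a higher number here means more inhibition of growth at the concentration tested, a lower number less inhibition of growth), compound 3 gives 94.3% and stands level with compound 2: the measured change is a number 1.7 percentage points higher from compound 2 to compound 3 (within the scatter) and nothing separates them. Compound 1 lies far off, with a number 94.7 percentage points higher from compound 1 to compound 3 (beyond the scatter) on record. Compound 4 `COc1cccc(NC(=O)C2(C(=O)Nc3ccc(Nc4ncc5cc(C(=O)N(C)C)n(C6CCCC6)c5n4)cc3)CC2)c1` carries 3-methoxyphenyl in place of 4-bromophenyl on an amide-type nitrogen as its only difference. The closest guide is a number 93 percentage points higher from compound 1 to compound 2 (beyond the scatter) for chloro in place of fluoro on an aromatic carbon, which shows that one small swap can separate the extremes. Going by the values given here, no measured compound carries 3-methoxyphenyl, so either extreme remains possible. A fall is therefore expected, an estimated a number 34.3 percentage points lower from compound 3 to compound 4 (beyond the scatter) of uncertain size. In this assay compound 4 is estimated at 60% with a range from 10% to 95%.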

Compound 4, percent growth inhibition at one concentration: 93.5%
Estimate against measurement, compound 4: 33.5 percentage points below; low and high end bracket the measured number.
By their numbers in this assay, from the lowest: compound 1; then compounds 2, 4 and 3 (each within the scatter of the next).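

In this assay the exchange on this amide-type nitrogen leaves the compounds level, with a number 0.8 percentage points lower from compound 3 to compound 4 (within the scatter) and with a number 0.9 percentage points higher from compound 2 to compound 4 (within the scatter) for methoxy in place of chloro on the same ring. Among the four compounds, only the fluoro compound stands apart, with a number 93.9 percentage points higher from compound 1 to compound 4 (beyond the scatter) for methoxy in place of fluoro. Nothing available explains this separation. Still open, as far as these compounds go, is whether an amine or a carboxylic acid in place of methoxy would keep this level, and whether the low value of compound 1 is particular to fluoro.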